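Swapping Amino for Methoxy on the Aryl Ketone

The source may report more compounds than this note shows. Statements on the series, on what has been measured and on what is new or still open speak of the compounds shown alone.

Three measured compounds share one core: compound 1 `COc1cc(-c2cc(/C=C/C(=O)c3ccc(N)cc3)[nH]n2)cc(OC)c1OC`, compound 2 `COc1ccc(-c2cc(/C=C/C(=O)c3ccc(N)cc3)[nH]n2)cc1OC` and compound 3 `COc1ccc(-c2cc(/C=C/C(=O)c3ccc(N)cc3)[nH]n2)cc1`. In a functional assay on PC-3 cells (Homo sapiens) for cytotoxicity, read by sulforhodamine B assay, with a stated time of 48 h, tested at 1 uM (on this read-out lower numbers stand for a stronger effect and higher numbers for a weaker effect at the one concentration tested), compound 1 gives 76%, the lowest of the three numbers, though its gap to compound 3 lies within the scatter. Compound 2 gives 89% and compound 3 gives 81%. The two recorded steps each remove a methoxy group from an aromatic carbon: a number 13 percentage points higher from compound 1 to compound 2 (beyond the scatter) and a number 8 percentage points lower from compound 2 to compound 3 (within the scatter), the first beyond the scatter and the second within it.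

Compound 4 `COc1ccc(C(=O)/C=C/c2cc(-c3cc(OC)c(OC)c(OC)c3)n[nH]2)cc1` differs from compound 1 in a different place on the molecule: methoxy in place of amino on an aromatic carbon. Among the compounds with values here, no measured pair shows this exchange. The two recorded steps concern methoxy groups on the other aromatic ring, so they bear on it only loosely; what they show is that a single methoxy change on this core can shift the read-out modestly or not at all. For compound 4 in this assay a step of about a number 6 percentage points higher from compound 1 to compound 4 (within the scatter) is therefore expected, most likely upward and small, possibly within the scatter. Compound 4 is estimated at 82%, within a range from 62% to 100%.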

Compound 4, a percentage reported as activity, at one concentration (the size of the read-out at that concentration, not a potency): 76%
For compound 4 the middle estimate is 6 percentage points above the measured one; measured number inside the range.
By their numbers in this assay, from the lowest: compounds 1, 4, 3 and 2 (each within the scatter of the next, the first and the last beyond it).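

At this position, on the ring carrying the ketone and para to a large group, the exchange of amino for methoxy can now be read directly in this assay: the step is no change at the digits printed from compound 1 to compound 4 (within the scatter). The swap removes the hydrogen-bond donor counted on the amino group and adds one heavy atom, yet the read-out at this one concentration does not separate the two groups, so on this core the amino group is not required to keep the number where compound 1 has it. Nothing measured here says why the two groups read alike.

On these data alone, what happens with other groups at this place stays open: a carboxylic acid, a dimethylamino group or a longer chain such as butoxy might read like amino and methoxy or quite differently. As far as these compounds go, the read-out is also taken at one concentration and gives no potency, so it remains open whether compound 1 and compound 4 would still match across a range of concentrations.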